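Bare ring nitrogen in compound 3: expected activity

The compounds below may be only part of what the source reports. "The series", "measured", "known", "first", "only" and "open" are said of these compounds alone.

Measured so far:
Compound 1, `CN(C[C@H]1Cc2c(cccc2N2CCN(c3cccc(C(F)(F)F)c3)CC2)CN1)[C@H]1CCCc2cccnc21`. In a functional assay on CCRF-CEM cells for antagonist activity at C-X-C chemokine receptor type 4 (Homo sapiens), read by calcium flux, with stated times of 25 min and 90 s (on this read-out higher numbers stand for weaker inhibition and lower numbers for stronger inhibition), compound 1 gives only a limit, > 16700 nM.
Compound 2, `CN(C[C@H]1Cc2c(cccc2N2CCN(c3ncccn3)CC2)CN1)[C@H]1CCCc2cccnc21`. In this assay compound 2 gives 30.7 nM.

Within the data shown here, compound 2 holds the only number in this assay; the other value is a limit (the limit of > 16700 nM in this assay, at which 1 of the 2 values shown sits). Among the measured compounds shown here, the one measured step, an at least 540-fold lower number from compound 1 to compound 2 (2.73 log units; beyond the scatter), swaps one aromatic group for another on the same ring nitrogen. Compound 3, `CN(C[C@H]1Cc2c(cccc2N2CCNCC2)CN1)[C@H]1CCCc2cccnc21`, differs from compound 2 by hydrogen in place of pyrimidin-2-yl on an amine nitrogen in a ring. For the measured compounds named here, no measured step removes the aromatic group entirely, so the swap only shows that this position matters strongly. A moderate loss is expected. Compound 3 is estimated at 150 nM, with a range of 20 nM to 1500 nM. The expected step is a 4.9-fold higher number from compound 2 to compound 3 (0.69 log units; beyond the scatter).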

Compound 3, half-maximal inhibitory concentration: 6.08 nM
Compound 3: the middle estimate sits 25-fold (1.39 log units) above what was measured, outside the stated range (below it).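

In this assay this ring nitrogen needs no aromatic group at all: hydrogen in place of pyrimidin-2-yl gives a 5.0-fold lower number from compound 2 to compound 3 (0.70 log units; beyond the scatter). Hydrogen in place of 3-(trifluoromethyl)phenyl gives an at least 2700-fold lower number from compound 1 to compound 3 (3.43 log units; beyond the scatter), so among the three compounds the bare nitrogen carries the lowest number. Compound 1 stands at a limit of the assay, so this second step has no exact size: the limit of > 16700 nM in this assay, at which 1 of the 3 values shown sits.

The compounds shown leave open whether a small group on this nitrogen, such as methyl or acetyl, keeps the low number of compound 3. Why the two aromatic groups differ so widely also stays unexplained.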